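The source may hold more compounds than are shown below. What is called first, only, known or untested is meant among the compounds shown, and "the series" means these compounds.

Measured in a functional assay on A549 cells (Homo sapiens) for cytotoxicity, read by MTT assay, with a stated time of 72 h; on this read-out higher numbers stand for weaker inhibition and lower numbers for stronger inhibition:
- compound 1 `COc1cccc(/C=C2\CCC/C(=C\c3ccccc3Cl)C2=O)c1OC`: > 20000 nM (a limit)
- compound 2 `COc1cccc(/C=C2\CCC/C(=C\c3ccc(Br)cc3)C2=O)c1OC`: > 20000 nM (a limit)

Compound 2 gives > 20000 nM, which is a limit and not a number. Among the compounds with values here, the only other value, that of compound 1, is also a limit.

Compound 3 `COc1cccc(/C=C2\CCC/C(=C\c3cccc(OC)c3OC)C2=O)c1` has not yet been measured. Its difference from compound 2 is 3-methoxyphenyl in place of 4-bromophenyl on a double-bonded chain carbon bound to a double-bonded ring carbon: 3-methoxyphenyl in place of 4-bromophenyl, on a double-bonded chain carbon bound to a double-bonded ring carbon.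

Within the data shown here, the one measured step bearing on this is a step that the two limits leave unreadable from compound 1 to compound 2. It involves a change at the same place, but it has no readable size, so no size or direction can be carried over from it. The expectation therefore rests on (the limit of > 20000 nM in this assay, at which 2 of the 2 values shown sit). In this assay, no step beyond the usual scatter is expected, and a further limit is the more likely report. The expected change is an at least 1.3-fold lower number from compound 2 to compound 3 (0.12 log units; that floor lies within the scatter). For compound 3 the estimated value is 15000 nM, with an expected range from 4000 nM to 30000 nM.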

Compound 3, half-maximal inhibitory concentration: 16400 nM
Compound 3: middle estimate off by 1.1-fold (0.04 log units), on the low side; the range from low to high includes it.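

In this assay, within the data shown here, compound 3 is the only compound of the three that carries a number rather than a limit, so 3-methoxyphenyl is the one group on a double-bonded chain carbon bound to a double-bonded ring carbon with a readable value. Against the 4-bromophenyl group the change gives an at least 1.2-fold lower number from compound 2 to compound 3 (0.08 log units; that floor lies within the scatter), and against the 2-chlorophenyl group it gives an at least 1.2-fold lower number from compound 1 to compound 3 (0.08 log units; that floor lies within the scatter); both are floors, so neither shows a difference beyond the scatter. The step between the two earlier compounds cannot be read, and the true size of the two new steps stays unknown because the reference values are limits: the limit of > 20000 nM in this assay, at which 2 of the 3 values shown sit.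

The compounds shown place only substituted phenyl groups at this position, which leaves open how an unsubstituted phenyl, an amine-bearing phenyl or a carboxylic acid there would read in this assay. Also open, on these data alone, is whether any group at this place can move the number clearly beyond the scatter from the limit.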